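Notes on an aryl piperidine amide series

The compounds below may be only part of what the source reports. "The series", "measured", "known", "first", "only" and "open" are said of these compounds alone.

Measured so far:
compound 1 `O=C1COc2ccc(NC(=O)C3CCN(c4cccc(Br)c4)CC3)cc2N1` — 330 nM
compound 2 `CC(=O)N1CCc2cc(NC(=O)C3CCN(c4cccc(C(F)(F)F)c4)CC3)ccc21` — > 9000 nM

For the measured compounds named here, in a functional assay for antagonist activity at transient receptor potential cation channel subfamily V member 1 (Homo sapiens), read by FLIPR and calcium flux (on this read-out higher numbers stand for weaker inhibition and lower numbers for stronger inhibition), compound 1 gives 330 nM, the only actual number in the set. Compound 2 reaches only > 9000 nM, which is a limit of this assay rather than a number (the limit of > 9000 nM in this assay, at which 1 of the 2 values shown sits). Going by the values given here, compound 2 differs from compound 1 in both the amide-bearing core and the group on the ring amine, so no single step connects them; their values say only that compound 1 inhibits where compound 2 shows no inhibition within the range covered.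

Compound 3 `Cc1ccccc1N1CCC(C(=O)Nc2ccc3c(c2)NC(=O)CO3)CC1` is not yet measured. It keeps the core of compound 1 and changes only the group on the ring amine: 2-methylphenyl in place of 3-bromophenyl on an amine nitrogen in a ring. Among the compounds with values here, no measured pair isolates this change. The step from compound 1 to compound 3 in this assay is expected to be modest and toward weaker inhibition, a 2.4-fold higher number from compound 1 to compound 3 (0.38 log units; beyond the scatter), with a wide margin of doubt. Compound 3 is estimated at 800 nM, with a range from 200 nM to 4000 nM.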

Compound 3, half-maximal inhibitory concentration: 150 nM
Compound 3: middle estimate off by 5.3-fold (0.73 log units), on the high side, outside the stated range (below it).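

With the core of compound 1 held fixed, the group on the amine nitrogen in the ring changes on its own here, and in this assay the swap to 2-methylphenyl moves toward stronger inhibition (a 2.2-fold lower number from compound 1 to compound 3 (0.34 log units; beyond the scatter)). This position therefore accepts 2-methylphenyl as well as 3-bromophenyl, and within this pair the bromine is not needed for inhibition. Nothing at hand gives a cause for this step.

Still open, going by these compounds, is whether 3-methylphenyl or 2-bromophenyl on the same core would separate the effect of the substituent from that of its place on the phenyl ring, and whether a cyclohexyl group would serve on that nitrogen. The value of compound 2 is a limit and not a number, and that compound differs in two places, so it adds nothing on this step.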